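A few compounds are considered here, and "the series" means these few. Any claim that something is new, unique, unknown or untested is made for them only; others in the source may bear on it.

Working notes on the series. Compound 1 `Cc1csc2cc([C@H](C)Nc3ncnc(N)c3C#N)c(-c3cccc(CN(C)CCCCN(C)Cc4ccccc4)c3)c(=O)n12` stands lowest of the two numbers measured in a physicochemical assay for acid dissociation, where compound 1 gives 9.1. For the measured compounds named here, its nearest neighbour, compound 2 `Cc1csc2cc([C@H](C)Nc3ncnc(N)c3C#N)c(-c3cccc(CN4CCC(CN(C)CC(C)C)CC4)c3)c(=O)n12`, gives 9.8 in this assay, a gap beyond the scatter; no single-point step links the two. Compound 3 `Cc1csc2cc([C@H](C)Nc3ncnc(N)c3C#N)c(-c3cccc(CN(C)CCCN4C[C@@H](C)O[C@@H](C)C4)c3)c(=O)n12` differs from compound 1 in one place: 2,6-dimethylmorpholin-4-yl in place of (benzyl(methyl)amino)methyl on a saturated chain carbon, three bonds along the chain from an amine nitrogen. Going by the values given here, no measured pair shows this change, so the direction rests on the structures alone. A small downward step a number 0.30 log units lower from compound 1 to compound 3 (within the scatter) is expected, barely beyond the scatter. Compound 3 is estimated at 8.8, between 8.2 and 9.4.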

Compound 3, acid dissociation constant: 8.5
Beside the measured number, compound 3's estimate is 0.30 log units above it; the measured number falls inside the stated range.
By their numbers in this assay, from the lowest: compound 3; then compound 1; then compound 2.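

In this assay, for the compounds shown here, 2,6-dimethylmorpholin-4-yl in place of (benzyl(methyl)amino)methyl gives a number 0.60 log units lower from compound 1 to compound 3 (beyond the scatter), the only measured reading of this change on a saturated chain carbon, three bonds along the chain from an amine nitrogen. The number at this position therefore shifts with the group it carries. No measurement at hand bears on what lies behind the shift.

The compounds shown do not separate the ring oxygen from the loss of the benzyl ring: piperidin-1-yl or unsubstituted morpholin-4-yl at this place would address that. Going by these compounds, the part played by the methyl groups and the defined stereocentres also stays open.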